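Solubility notes: the pyridine methyl removed

A few compounds are considered here, and "the series" means these few. Any claim that something is new, unique, unknown or untested is made for them only; others in the source may bear on it.

The series is followed in a physicochemical assay for solubility, read by HPLC, using the shake flask method, measured as kinetic solubility, with a stated time of 20 h, at pH 6.5, tested at 200 uM; on this read-out lower numbers stand for lower solubility and higher numbers for higher solubility. Compound 1 `Cc1ccc(-c2ccnc3ccc(-c4cccc(S(N)(=O)=O)c4)nc23)cn1` gives only a limit of the assay, < 5000 nM. Compound 2 `NCCNS(=O)(=O)c1cccc(Nc2ccc3nccc(-c4ccncc4)c3n2)c1` gives 200000 nM in this assay, and compound 3 `c1cc(-c2ccnc3ccc(NC4CC4)nc23)ccn1` gives 90000 nM. Of the three values, one sits at the limit of < 5000 nM in this assay, at which 1 of the 3 values shown sits, and that one belongs to compound 1. Compound 4 `NS(=O)(=O)c1cccc(-c2ccc3nccc(-c4cccnc4)c3n2)c1` is not yet measured. It differs from compound 1 by hydrogen in place of methyl on an aromatic carbon. For the measured compounds named here, no measured pair in the set carries this change, so its size rests on expectation alone: a small step upward, or none beyond the scatter, is expected, read as an at least 1.2-fold higher number from compound 1 to compound 4 (0.07 log units; that floor lies within the scatter). For compound 4 the estimate is 6000 nM, with a range from 2000 nM to 20000 nM, and a real chance that this assay again reports only a limit.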

Compound 4, solubility: < 5000 nM
Compound 4: no number, only a limit; the forecaster's own chance of this, stated with the estimate: 50%; at least 1.2-fold (0.07 log units) between middle value and limit.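

In this assay, for the compounds shown here, compound 1 and compound 4 both give only a limit, so no step between them can be read. As far as these compounds go, the true values of both, and so the size of the change from 6-methylpyridin-3-yl to pyridin-3-yl, stay open.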